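Benzyl in Place of 4-Methoxyphenyl on a Non-Toxic Core

The source may report more compounds than this note shows. Statements on the series, on what has been measured and on what is new or still open speak of the compounds shown alone.

compound 1 `CCC1(Cc2ccccc2)OS(=O)(=O)C=C1OCc1ccc(OC)cc1`: limit >= 200000 nM
compound 2 `CC1(Cc2ccccc2)OS(=O)(=O)C=C1OCc1ccccc1`: limit > 400000 nM
compound 3 `CCC1(CC)OS(=O)(=O)C=C1OCc1ccccc1`: limit > 400000 nM

In an ADME assay on HEL cells (Homo sapiens) for cytotoxicity, with a stated time of 3 days (on this read-out lower numbers stand for higher toxicity in this test and higher numbers for lower toxicity in this test), compound 1 reaches only a limit, >= 200000 nM. Compound 2 likewise stops at a limit, > 400000 nM. Compound 3 also gives a limit, > 400000 nM. For the measured compounds named here, compound 1 therefore stands at the limit of >= 200000 nM in this assay, at which 1 of the 3 values shown sits, whereas the other two sit at the limit of > 400000 nM in this assay, at which 2 of the 3 values shown sit; none of the three shows a number, so no step between measured compounds can be drawn.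

Compound 4 `CCC1(Cc2ccccc2)OS(=O)(=O)C=C1OCCc1ccccc1` differs from compound 1 by benzyl in place of 4-methoxyphenyl on a saturated chain carbon bound to an oxygen on an unsaturated carbon. Since every measured compound stays at a limit in this assay, no shift beyond the scatter is expected from this exchange. Compound 4 is accordingly expected to give 400000 nM, between 200000 nM and 800000 nM, a step that the limit leaves unreadable from compound 1 to compound 4 that most likely ends in another limit.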

Compound 4, minimum cytotoxic concentration: >= 20000 nM
Compound 4 ended at the assay's limit; the forecaster's own chance of this, stated with the estimate: 85%; the middle value lies beyond the limit too.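

Compound 1 and compound 4 both stop at limits in this assay, and the step between them cannot be read. The compounds shown leave open at what concentration any of them turns toxic in this assay.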